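Cyclic tertiary amide in place of the oxolanyl amide

A few compounds are considered here, and "the series" means these few. Any claim that something is new, unique, unknown or untested is made for them only; others in the source may bear on it.

Going by the values given here, compound 3 `CCN(CC)S(=O)(=O)c1ccc(S(=O)(=O)N2CCC[C@@H](C(=O)N[C@@H]3CCOC3)C2)cc1` gives 750 nM in a functional assay on MIA PaCa-2 cells (Homo sapiens) for inhibition, read by MTT assay, with a stated time of 7 days (a higher number here means a weaker inhibitor, a lower number a stronger inhibitor), and stands second highest of the three numbers measured so far. Compound 1 `CCN(CC)S(=O)(=O)c1ccc(S(=O)(=O)N2CCC[C@@H](C(=O)N[C@H]3CC[C@H](OC)CC3)C2)cc1` gives 1350 nM and compound 2 `CCN(CC)S(=O)(=O)c1ccc(S(=O)(=O)N2CCC[C@@H](C(=O)N3CCOCC3)C2)cc1` gives 350 nM in the same test. Compound 4 `CCN(CC)S(=O)(=O)c1ccc(S(=O)(=O)N2CCC[C@@H](C(=O)N3CCC(C(F)F)CC3)C2)cc1` differs from compound 3 by 4-(difluoromethyl)piperidin-1-yl in place of (oxolan-3-yl)amino on a carbonyl carbon and is not yet measured. Among the compounds with values here, two measured steps bear on this change: a 2.1-fold higher number from compound 2 to compound 3 (0.33 log units; beyond the scatter) and a 3.9-fold lower number from compound 1 to compound 2 (0.59 log units; beyond the scatter) both show that the cyclic tertiary amide carries the lower number than the secondary amide. Compound 4 is therefore expected to give a modest step towards a lower number in this assay as the step of a 2.1-fold lower number from compound 3 to compound 4 (0.33 log units; beyond the scatter) would read. Compound 4 is estimated at 350 nM with an expected range from 120 nM to 1000 nM around it.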

Compound 4, half-maximal inhibitory concentration: 420 nM
For compound 4 the middle estimate is 1.2-fold (0.08 log units) below the measured one; measured number inside the range.
By their numbers in this assay, from the lowest: compounds 2, 4, 3 and 1 (each within the scatter of the next, the first and the last beyond it).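

In this assay the 4-(difluoromethyl)piperidin-1-yl group on this carbonyl carbon gives a 1.8-fold lower number from compound 3 to compound 4 (0.25 log units; within the scatter) and a 1.2-fold higher number from compound 2 to compound 4 (0.08 log units; within the scatter) and so does not separate from the (oxolan-3-yl)amino or morpholin-4-yl groups. Only a 3.2-fold lower number from compound 1 to compound 4 (0.51 log units; beyond the scatter) lies beyond the scatter, so compound 4, like compound 2, stands clear of the (4-methoxycyclohexyl)amino group alone. Nothing measured here explains these numbers. The compounds shown leave open how piperidin-1-yl without the difluoromethyl group, or an open-chain dimethylamino group, would read on this carbonyl carbon.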